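Ethoxy in Place of Acetamido: Expected Cytotoxicity of Compound 4

The compounds below may be only part of what the source reports. "The series", "measured", "known", "first", "only" and "open" are said of these compounds alone.

Compound 1 is `CC(=O)Nc1cccc(-c2ccc(C(=O)N(Cc3cccc(OCCCCCC(=O)O)c3)C(C)C)cc2)c1`. In an ADME assay on HEK293 cells (Homo sapiens) for cytotoxicity, read by CellTiter-Glo and resazurin assay, with a stated time of 72 h (a higher number here means that more compound is needed for the effect, a lower number that less compound is needed), compound 1 reaches only the assay limit, > 26000 nM.
Compound 2 is `CC(C)N(Cc1cccc(OCCCCCC(=O)O)c1)C(=O)c1ccc(-c2cccc(Cl)c2)cc1`. In this assay compound 2 likewise gives only a limit, > 21900 nM.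
Compound 3 is `CCOC(=O)CCCCCOc1cccc(CN(C(=O)c2ccc(-c3cccc(NC(C)=O)c3)cc2)C(C)C)c1`. In this assay compound 3 also returns a limit rather than a number, > 26000 nM.

Compound 3 therefore stands at the upper edge of what the assay reports, at the limit of > 26000 nM in this assay, at which 2 of the 3 values shown sit, and the remaining value sits at the limit of > 21900 nM in this assay, at which 1 of the 3 values shown sits. Both steps that were measured, a step that the two limits leave unreadable from compound 1 to compound 2 and a step that the two limits leave unreadable from compound 1 to compound 3, join two limits and so show no readable size or direction.

Compound 4 is `CCOC(=O)CCCCCOc1cccc(CN(C(=O)c2ccc(-c3cccc(OCC)c3)cc2)C(C)C)c1`. Its difference from compound 3 is ethoxy in place of acetamido on an aromatic carbon. The one measured step that also removes an acetamido group, a step that the two limits leave unreadable from compound 1 to compound 2, is unreadable, so nothing shown lets a direction be assigned; all three compounds are at or beyond the ceiling of this assay.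

Compound 4 is therefore expected to behave like its neighbours, with an estimated step that the limit leaves unreadable from compound 3 to compound 4, meaning no change that the data can resolve. The estimate for compound 4 in this assay is 30000 nM, with a range from 13000 nM to 100000 nM, and most likely the assay will again report only a limit.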

Compound 4, half-maximal effective concentration: > 22300 nM
Compound 4 ended at the assay's limit; the forecaster's own chance of this, stated with the estimate: 80%; the middle value lies beyond the limit too.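

In this assay compound 4 gives only a limit, > 22300 nM. Compound 3 likewise gives only a limit, > 26000 nM. Within the data shown here, no new step can therefore be read between compound 3 and compound 4. The compounds shown leave open where the cytotoxicity of these four compounds actually lies, and whether ethoxy in place of acetamido changes it at all.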